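The source may report more compounds than this note shows. Statements on the series, on what has been measured and on what is new or still open speak of the compounds shown alone.

Within the data shown here, in an ADME assay on the whole organism (Rattus norvegicus, strain Sprague-Dawley) for pharmacokinetics, using cassette dosing, at a dose of 1 mg/kg by the oral route (a higher number here means that a larger share of the oral dose reaches the circulation, a lower number that a smaller share of the oral dose reaches the circulation), three compounds have numbers so far. Compound 1 (`O[C@]1(Cc2cc(-c3cn[nH]c3)on2)CC[C@@H](Cc2ccc(C(F)(F)F)cc2)CC1`) gives 67.5%, compound 2 (`O=C(c1cc(-c2ccc(=O)[nH]c2)on1)N1CCC(Cc2ccccc2)CC1`) gives 18.4%, and compound 3 (`O=C(Nc1ccc2[nH]c(=O)oc2c1)C(=O)N1CCN(c2ccc(Cl)cc2)CC1`) gives 17.8%. Compound 3 thus lies within the scatter of compound 2, while compound 1 stands beyond the scatter above it. Compound 4 (`O=C(Nc1ccc2[nH]c(=O)oc2c1)C(=O)N1CCN(c2ccc(C(F)(F)F)cc2)CC1`) differs from compound 3 in one place: trifluoromethyl in place of chloro on an aromatic carbon, para to a large group. Among the measured compounds shown here, no measured pair shows this change, so the data offer no direct guide to its size. The expected step, a number 2.2 percentage points higher from compound 3 to compound 4 (within the scatter), stays within the scatter, with no firm direction. For compound 4 the estimated value is 20%, with an expected range from 8% to 36%.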

Compound 4, oral bioavailability: 24.8%
Estimate against measurement, compound 4: 4.8 percentage points below; the range from low to high includes it.
By their numbers in this assay, from the lowest: compounds 3, 2 and 4 (each within the scatter of the next); then compound 1.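

In this assay, among these compounds, this pair gives the first measured reading for trifluoromethyl in place of chloro on an aromatic carbon, para to a large group (a number 7 percentage points higher from compound 3 to compound 4 (within the scatter)). The step lies within the scatter, so the move from 4-chlorophenyl to 4-(trifluoromethyl)phenyl sets no firm direction at this position. No measurement at hand bears on the reason for this result. On these data alone, it remains open whether an amine, a carboxylic acid or a longer chain at this position would shift the number beyond the scatter. The same exchange on another core also remains untested by any pair shown here.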